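From methoxy to 4-chlorophenyl at the cytotoxicity limit

A few compounds are considered here, and "the series" means these few. Any claim that something is new, unique, unknown or untested is made for them only; others in the source may bear on it.

Measured so far in an ADME assay on HCT-116 cells (Homo sapiens) for cytotoxicity, read by CellTiter-Glo, with a stated time of 72 h; a higher number here means a weaker inhibitor, a lower number a stronger inhibitor:
Compound 1 `CC1CCN(C2CCN(S(=O)(=O)c3cccc(Cl)c3)CC2)CC1` gives > 5000 nM (a limit of the assay)
Compound 2 `COc1cccc(S(=O)(=O)N2CCC(N3CCC(C)CC3)CC2)c1` gives > 5000 nM (a limit of the assay)

In this assay compound 2 stands at > 5000 nM as a limit and not as a number. The two measured compounds together show only the limit of > 5000 nM in this assay, at which 2 of the 2 values shown sit, and give no number for either of them. Among the compounds with values here, the one measured step, a step that the two limits leave unreadable from compound 1 to compound 2, replaces a small group at the same aromatic carbon that changes next, but it offers no size to carry forward.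

Compound 3 `CC1CCN(C2CCN(S(=O)(=O)c3cccc(-c4ccc(Cl)cc4)c3)CC2)CC1` has 4-chlorophenyl in place of methoxy on an aromatic carbon, meta to a large group, and the change counts as 4-chlorophenyl in place of methoxy on an aromatic carbon on the shared core. With compound 2 at > 5000 nM as a limit, the expected direction in this assay can only be toward a lower number, or no readable change at all. The expected step is an at least 2.0-fold lower number from compound 2 to compound 3 (0.30 log units; that floor lies within the scatter) and it remains a rough estimate. For compound 3 the estimate is 2500 nM with an expected range from 500 nM to 5000 nM in this assay, and a further limit would be no surprise.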

Compound 3, half-maximal inhibitory concentration: > 5000 nM
Compound 3 was reported as a limit (the forecaster's own chance of this, stated with the estimate: 50%); middle value at least 2.0-fold (0.30 log units) from the limit.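

In this assay compound 3 gives > 5000 nM, a limit of the assay and not a number. No step among compound 1, compound 2 and compound 3 can be read, and all three share one limit: the limit of > 5000 nM in this assay, at which 3 of the 3 values shown sit.

The compounds shown leave open whether any group at this aromatic carbon gives a readable number in this assay.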